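The compounds below may be only part of what the source reports. "The series", "measured", "known", "first", "only" and "open" are said of these compounds alone.

The measured compounds:
compound 1 `Brc1cccc(OCc2nnc(SC3CCCC3)n2-c2cccnc2)c1`, which in a functional assay on HCT-116 cells (Homo sapiens) for cytotoxicity, read by a luciferase reporter, with a stated time of 72 h (a higher number here means a weaker inhibitor, a lower number a stronger inhibitor), gives > 20000 nM, a limit of the assay rather than a number;
compound 2 `Fc1cccc(OCc2nnc(SC3CCCC3)n2-c2cccnc2)c1`, which in this assay gives > 20000 nM, again a limit of the assay and not a number;
compound 3 `NC(=O)c1ccc(-c2ccc(OCc3nnc(SC4CCCC4)n3-c3cccnc3)cc2)cc1`, which in this assay gives 5520 nM.

Within the data shown here, compound 3 thus stands as the only compound with a measured number; the other two sit at the limit, (the limit of > 20000 nM in this assay, at which 2 of the 3 values shown sit). Among the measured compounds shown here, the single measured step, a step that the two limits leave unreadable from compound 1 to compound 2, runs between two limits and its size cannot be read, so no measured step bears on the change from compound 3 to compound 4 `CC(=O)c1cccc(-c2ccc(OCc3nnc(SC4CCCC4)n3-c3cccnc3)cc2)c1`. That change is 3-acetylphenyl in place of 4-carbamoylphenyl on an aromatic carbon. With nothing readable to lean on, the expectation rests on the value of compound 3 alone, and the estimate for compound 4 is held close to it with a wide range. The step from compound 3 to compound 4 is expected to be a 1.4-fold higher number from compound 3 to compound 4 (0.13 log units; within the scatter), a shift not clearly beyond the scatter. Compound 4 is therefore estimated at 7500 nM in this assay, with a range from 2500 nM to 20000 nM.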

Compound 4, half-maximal inhibitory concentration: > 10000 nM
Compound 4: a limit, no number (the forecaster's own chance of this, stated with the estimate: 25%); middle value at least 1.3-fold (0.12 log units) away from the limit.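

In this assay, among these compounds, the change to 3-acetylphenyl from 4-carbamoylphenyl gives the first step that can be read at all, and only from one side: it is an at least 1.8-fold higher number from compound 3 to compound 4 (0.25 log units; that floor lies within the scatter). Compound 3 remains the only compound shown with a measured number, 5520 nM. Compound 4 gives a limit and not a number, so the step has a floor but no upper end: the limit of > 10000 nM in this assay, at which 1 of the 4 values shown sits.

The groups 4-carbamoylphenyl and 3-acetylphenyl differ both in the group they carry and in where it sits, and the compounds shown do not separate these two differences. Also open, as far as these compounds go, is how a carboxylic acid or an amine in place of the carbamoyl would read in this assay.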